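Methoxy on the fused ring across two linker types

A few compounds are considered here, and "the series" means these few. Any claim that something is new, unique, unknown or untested is made for them only; others in the source may bear on it.

Compound 1 `COc1ccc2c(C(=O)c3cc(OC)c(OC)c(OC)c3N)c[nH]c2c1` gives 13 nM in a functional assay on MCF7 cells (Homo sapiens) for cytotoxicity, read by sulforhodamine B assay, with a stated time of 48 h; on this read-out higher numbers stand for weaker inhibition of growth and lower numbers for stronger inhibition of growth. Compound 2 `COc1cc2[nH]cc(C(=O)c3cc(OC)c(OC)c(OC)c3N)c2cc1OC` carries one change from compound 1, (methoxy in place of hydrogen on an aromatic carbon), and in this assay compound 2 gives 38500 nM; the step is a 3000-fold higher number from compound 1 to compound 2 (3.47 log units; beyond the scatter). Compound 3 `COc1ccc2c(Cc3cc(OC)c(OC)c(OC)c3N)c[nH]c2c1` has a different core, and the difference between the two cores is not broken down here; in this assay compound 3 gives 1830 nM. Compound 4 `COc1cc2[nH]cc(Cc3cc(OC)c(OC)c(OC)c3N)c2cc1OC` is compound 3 with the same change, (methoxy in place of hydrogen on an aromatic carbon), so the pair compound 3 to compound 4 repeats the pair compound 1 to compound 2. A large upward step is expected from compound 3 to compound 4, an 82-fold higher number from compound 3 to compound 4 (1.91 log units; beyond the scatter), resting on compound 1 and compound 2 and their step of a 3000-fold higher number from compound 1 to compound 2 (3.47 log units; beyond the scatter), but somewhat smaller since compound 3 already starts at 1830 nM. For compound 4 the expected value in this assay is 150000 nM, with the estimate spanning 30000 nM to 800000 nM.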

Compound 4, concentration for 50% growth inhibition: "not active" (no number reported)
Compound 4 has no reported number here; no gap can be computed for the estimate.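

Within the data shown here, compound 4 is reported as not active, without a number, so no step from compound 3 to compound 4 can be read. As far as these compounds go, how large the methoxy change is on this core stays open, and no measured property bears on the result.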